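Notes on the series: compound 3 to compound 4

The source may report more compounds than this note shows. Statements on the series, on what has been measured and on what is new or still open speak of the compounds shown alone.

Measured in a functional assay on Hs 683 cells (Homo sapiens) for inhibition, read by colorimetric assay and MTT assay, with a stated time of 72 h; on this read-out lower numbers stand for stronger inhibition and higher numbers for weaker inhibition:
compound 1, `Cc1ccc(C(=O)NNC(=S)Nc2csc(-c3ccccc3)c2)cc1`: 37000 nM
compound 2, `COc1ccc(C(=O)NNC(=S)Nc2csc(-c3ccccc3)c2)cc1`: 35000 nM
compound 3, `COc1ccc(C(=O)NNC(=S)Nc2csc(-c3ccc(C)cc3)c2)cc1`: 12000 nM

Compound 3 holds the lowest of the three numbers in this assay. Its nearest neighbour is compound 2, reached by a 2.9-fold lower number from compound 2 to compound 3 (0.46 log units; beyond the scatter), a change that adds a methyl to the phenyl on the thiophene side; compound 1 sits a little further off still, and the move a 1.1-fold lower number from compound 1 to compound 2 (0.02 log units; within the scatter) between compound 1 and compound 2 does not separate them.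

Compound 4, `Cc1ccc(-c2cc(NC(=S)NNC(=O)c3ccc(O)cc3)cs2)cc1`, is the next step from compound 3: hydrogen in place of methyl on an oxygen on an aromatic ring. For the measured compounds named here, no measured pair tests this exact change. The closest comparison is a 1.1-fold lower number from compound 1 to compound 2 (0.02 log units; within the scatter), which alters the same aromatic carbon's substituent (methyl against methoxy) and lies within the scatter; it says nothing about uncapping the oxygen. The step of a 2.9-fold lower number from compound 2 to compound 3 (0.46 log units; beyond the scatter) concerns the other ring and does not transfer. Going by the values given here, with no direct precedent and the one related substituent swap flat, the expectation is a small step at most, a 1.1-fold higher number from compound 3 to compound 4 (0.03 log units; within the scatter), in no firm direction. Compound 4 is therefore estimated at 13000 nM, with a likely range of 5000 nM to 35000 nM in this assay.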

Compound 4, half-maximal inhibitory concentration: 49000 nM
Estimate against measurement, compound 4: 3.8-fold (0.58 log units) below; the whole stated range lies below it.
By their numbers in this assay, from the lowest: compound 3; then compounds 2, 1 and 4 (each within the scatter of the next).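

In this assay the capped oxygen on the aromatic ring proves not to be a silent spot: going from 4-methoxyphenyl to 4-hydroxyphenyl gives a 4.1-fold higher number from compound 3 to compound 4 (0.61 log units; beyond the scatter), so removing that methyl weakens inhibition on the core of compound 3. For the compounds shown here, the only earlier change at this ring carbon, a 1.1-fold lower number from compound 1 to compound 2 (0.02 log units; within the scatter), gave no readable shift, so the flat result for methyl against methoxy does not extend to hydroxy, at least across these two backgrounds. What lies behind the loss cannot be stated, as nothing on hand bears on this result.

On these data alone, the hydroxy group is seen only alongside the methyl on the phenyl of the thiophene side, so whether the same loss appears on the core of compound 2, without that methyl, remains open. Also open, as far as these compounds go, is how other groups on this ring carbon would read, such as an ethoxy, an amine or a carboxylic acid, and therefore whether the loss belongs to the hydroxy group alone or to any departure from methoxy.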